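A few compounds are considered here, and "the series" means these few. Any claim that something is new, unique, unknown or untested is made for them only; others in the source may bear on it.

Measured in a functional assay on MCF-10A cells (Homo sapiens) for antiproliferative activity, with a stated time of 48 h; on this read-out higher numbers stand for an effect only at larger amounts of compound and lower numbers for an effect already at smaller amounts:
- compound 1 `COc1ccc2nc(C)cc(NCc3ccc(C)cc3)c2c1`: 22400 nM
- compound 2 `COc1ccc2nc(C)cc(NCc3cccc(F)c3)c2c1`: 14700 nM
- compound 3 `COc1ccc2nc(C)cc(NCc3cccc(OC(F)F)c3)c2c1`: 14300 nM

Compound 2, at 14700 nM, lies within the scatter of both compound 1 and compound 3. Compound 4 `COc1ccc2nc(C)cc(NCc3ccc(OC)c(F)c3)c2c1` differs from compound 2 by one added group, methoxy in place of hydrogen on an aromatic carbon. Two measured steps offer guidance, though neither is this same change. Placing difluoromethoxy in place of fluoro on an aromatic carbon gives a 1.0-fold lower number from compound 2 to compound 3 (0.01 log units; within the scatter). Placing 3-fluorophenyl in place of 4-methylphenyl gives a 1.5-fold lower number from compound 1 to compound 2 (0.18 log units; within the scatter). With both steps this small, no step beyond the scatter is expected in this assay. The expected step is a 1.1-fold lower number from compound 2 to compound 4 (0.02 log units; within the scatter). For compound 4 the estimated value is 14000 nM, with an expected range from 6000 nM to 30000 nM.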

Compound 4, half-maximal effective concentration: 10300 nM
Compound 4: middle estimate off by 1.4-fold (0.13 log units), on the high side, and the stated range covers the measured number.
By their numbers in this assay, from the lowest: compounds 4, 3, 2 and 1 (each within the scatter of the next, the first and the last beyond it).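

In this assay, methoxy in place of hydrogen gives a 1.4-fold lower number from compound 2 to compound 4 (0.15 log units; within the scatter). For the compounds shown here, this shows that the aromatic carbon ortho to a fluoro group and para to a large group can carry methoxy without a step beyond the scatter, a position the earlier compounds left empty. No measurement here bears on why the step is this size. On these data alone, whether an amine or a carboxylic acid on this carbon would give a step beyond the scatter remains open. So does whether methoxy would give a similar step without the fluoro group.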